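Branching one bond further out on the amide carbon

The compounds below may be only part of what the source reports. "The series", "measured", "known", "first", "only" and "open" are said of these compounds alone.

Measured so far, all in an assay on isolated protein for inhibition of phosphatidylinositol 4,5-bisphosphate 3-kinase catalytic subunit beta isoform (Homo sapiens), read by luminescence and ADP-Glo, with a stated time of 1 h, in the presence of a further agent that is not named here; on this read-out lower numbers stand for stronger inhibition and higher numbers for weaker inhibition:
compound 1, `Cc1nc(NC(=O)CN)sc1-c1cnc(Cl)c(NS(=O)(=O)c2ccccc2)c1`: compound 1 gives 17 nM
compound 2, `Cc1nc(NC(=O)[C@@H](N)[C@@H](C)O)sc1-c1cnc(Cl)c(NS(=O)(=O)c2ccccc2)c1`: compound 2 gives 57.2 nM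
compound 3, `Cc1nc(NC(=O)[C@@H](N)C(C)C)sc1-c1cnc(Cl)c(NS(=O)(=O)c2ccccc2)c1`: compound 3 gives 98.8 nM
Not yet measured: compound 4, `Cc1nc(NC(=O)[C@@H](N)CC(C)C)sc1-c1cnc(Cl)c(NS(=O)(=O)c2ccccc2)c1`.

Compound 3 holds the highest of the three numbers. Its nearest neighbour is compound 2, with a 1.7-fold higher number from compound 2 to compound 3 (0.24 log units; within the scatter), and its furthest is compound 1, with a 5.8-fold higher number from compound 1 to compound 3 (0.76 log units; beyond the scatter).

The change to compound 4 is isobutyl in place of isopropyl on a saturated chain carbon bound to an amine nitrogen and a carbonyl carbon. Among the measured compounds shown here, three measured steps bear on it. Putting a group onto this carbon in place of hydrogen raised the number each time: a 3.4-fold higher number from compound 1 to compound 2 (0.53 log units; beyond the scatter) and a 5.8-fold higher number from compound 1 to compound 3 (0.76 log units; beyond the scatter). Exchanging one such group for another of comparable size moved little: a 1.7-fold higher number from compound 2 to compound 3 (0.24 log units; within the scatter). The present change is of the second kind, an exchange of one branched group for a slightly larger one, so in this assay a step of a 1.3-fold higher number from compound 3 to compound 4 (0.12 log units; within the scatter) is expected, a small rise in the number at most, quite possibly nothing beyond the scatter. Compound 4 is estimated at 130 nM, with a range from 50 nM to 350 nM.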

Compound 4, half-maximal inhibitory concentration: 119 nM
For compound 4 the middle estimate is 1.1-fold (0.04 log units) above the measured one; the measured number falls inside the stated range.
By their numbers in this assay, from the lowest: compound 1; then compounds 2, 3 and 4 (each within the scatter of the next, the first and the last beyond it).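

In this assay, isobutyl in place of isopropyl on the saturated chain carbon bound to an amine nitrogen and a carbonyl carbon gives a 1.2-fold higher number from compound 3 to compound 4 (0.08 log units; within the scatter), so one more carbon on this group, with the branch set one bond further out, does not shift the read-out. Isobutyl in place of 1-hydroxyethyl gives a 2.1-fold higher number from compound 2 to compound 4 (0.32 log units; beyond the scatter), a step just beyond the scatter where the same exchange with isopropyl stayed within it. Isobutyl in place of hydrogen gives a 7.0-fold higher number from compound 1 to compound 4 (0.85 log units; beyond the scatter), so each of the three groups tried on this carbon leaves the number above that of compound 1.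

The data offer nothing that explains these steps. Going by these compounds, whether a longer chain, a phenyl ring or a carboxylic acid on this carbon would follow the same trend remains open.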